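Chloro in Place of Fluoro on Compound 3

This account rests on a few compounds, and the source may have more. Where it says the series, first, only, none or still open, it means among the compounds named here.

In a functional assay on a cell-free system (Platelet, plasma, Homo sapiens) for inhibition (on this read-out lower numbers stand for stronger inhibition and higher numbers for weaker inhibition), compound 1 (`Cc1ccc(N(CCN2CCC(OCC(=O)O)CC2)C(=O)c2ccc(F)cc2)cc1`) gives 970 nM, compound 2 (`Cc1ccc(N(CCN2CCC(OCC(=O)O)CC2)C(=O)c2ccc(Cl)cc2)cc1`) gives 690 nM and compound 3 (`O=C(O)COC1CCN(CCN(C(=O)c2ccc(F)cc2)c2ccc(Cl)cc2)CC1`) gives 2000 nM. Compound 3 therefore carries the highest number of the three, and its gaps to both others lie beyond the scatter. The next structure is compound 4 (`O=C(O)COC1CCN(CCN(C(=O)c2ccc(Cl)cc2)c2ccc(Cl)cc2)CC1`), reached through (chloro in place of fluoro on an aromatic carbon), which puts chloro in place of fluoro on an aromatic carbon, para to a large group.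

The same exchange has been measured once, as a 1.4-fold lower number from compound 1 to compound 2 (0.15 log units; within the scatter), and that step stays within the scatter. The other measured step, a 2.1-fold higher number from compound 1 to compound 3 (0.31 log units; beyond the scatter), is a modest one, but it replaces methyl with chloro, so it bears on the new change only indirectly: it sets the starting point. No step beyond the scatter is therefore expected, only a slight drift towards a lower number. The expected step is a 1.4-fold lower number from compound 3 to compound 4 (0.15 log units; within the scatter). Compound 4 is estimated at 1400 nM, with an expected range of 750 nM to 2600 nM.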

Compound 4, half-maximal inhibitory concentration: 1500 nM
For compound 4 the middle estimate is 1.1-fold (0.03 log units) below the measured one, and the stated range covers the measured number.
By their numbers in this assay, from the lowest: compounds 2, 1, 4 and 3 (each within the scatter of the next, the first and the last beyond it).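

In this assay, the change from 4-fluorophenyl to 4-chlorophenyl now has a second reading, a 1.3-fold lower number from compound 3 to compound 4 (0.12 log units; within the scatter), so the small step seen on the core carrying methyl also holds on the core carrying chloro: the same change on two cores in this assay, a 1.4-fold lower number (0.15 log units; within the scatter) from compound 1 to compound 2 and a 1.3-fold lower number (0.12 log units; within the scatter) from compound 3 to compound 4, 1.1-fold (0.02 log units) apart, within the scatter of two such steps. The chloro in place of methyl change also gains a second reading, a 2.2-fold higher number from compound 2 to compound 4 (0.34 log units; beyond the scatter), and its size is much the same whether fluoro or chloro sits at the position para to a large group: the same change on two cores in this assay, a 2.1-fold higher number (0.31 log units; beyond the scatter) from compound 1 to compound 3 and a 2.2-fold higher number (0.34 log units; beyond the scatter) from compound 2 to compound 4, 1.1-fold (0.02 log units) apart, within the scatter of two such steps. Across these four compounds, neither change alters the size of the other.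

As far as these compounds go, whether bromo or methoxy at this position would give a step beyond the scatter remains open. So does the effect of a longer chain leading to the carboxylic acid.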